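Cinnamate sulfonate series: ester to anilide, aryl swap on amide

This account rests on a few compounds, and the source may have more. Where it says the series, first, only, none or still open, it means among the compounds named here.

Numbers so far in a toxicity assay on L02 cells (Homo sapiens) for cytotoxicity, read by MTT assay, with a stated time of 24 h; on this read-out higher numbers stand for lower toxicity in this test and lower numbers for higher toxicity in this test:
compound 1 `CCCOC(=O)/C=C/c1ccc(OS(=O)(=O)c2ccc(Cl)cc2)c(OC)c1`: 150000 nM
compound 2 `COc1cc(/C=C/C(=O)OCC(C)C)ccc1OS(=O)(=O)c1ccc(Cl)cc1`: 103000 nM
compound 3 `COc1cc(/C=C/C(=O)Nc2cccc(C)c2)ccc1OS(=O)(=O)c1ccc(Cl)cc1`: 73500 nM

Compound 3 gives the lowest of the three numbers in this assay, though only its gap to compound 1 is beyond the scatter. The measured steps are small: a 1.5-fold lower number from compound 1 to compound 2 (0.16 log units; within the scatter); a 2.0-fold lower number from compound 1 to compound 3 (0.31 log units; beyond the scatter); a 1.4-fold lower number from compound 2 to compound 3 (0.15 log units; within the scatter).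

Compound 4 `COc1cc(/C=C/C(=O)Nc2ccc(I)cc2)ccc1OS(=O)(=O)c1ccc(Cl)cc1` keeps the amide of compound 3 and changes only the aryl group on the nitrogen: 4-iodophenyl in place of 3-methylphenyl on an amide-type nitrogen. Within the data shown here, no measured step alters a group on the amide nitrogen, so none bears directly on this change; the ester-to-anilide steps above show that changes at this end of the molecule moved this assay little. The expectation is therefore a step near or within the scatter, a 1.2-fold lower number from compound 3 to compound 4 (0.09 log units; within the scatter), with no clear direction.

Compound 4 is estimated at 60000 nM, within 25000 nM to 150000 nM.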

Compound 4, half-maximal cytotoxic concentration: 39400 nM
Compound 4: the middle estimate sits 1.5-fold (0.18 log units) above what was measured, within the range that was stated.
By their numbers in this assay, from the lowest: compounds 4, 3, 2 and 1 (each within the scatter of the next, the first and the last beyond it).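

In this assay the aryl swap on the amide-type nitrogen gives a 1.9-fold lower number from compound 3 to compound 4 (0.27 log units; within the scatter), so 3-methylphenyl and 4-iodophenyl are not separated at this position. The 4-iodophenyl anilide stands clear of both esters, with a 2.6-fold lower number from compound 2 to compound 4 (0.42 log units; beyond the scatter) and a 3.8-fold lower number from compound 1 to compound 4 (0.58 log units; beyond the scatter), whereas compound 3 was clear only of compound 1. No measured evidence bears on the reason for these differences.

The compounds shown leave open how far the aryl group matters at all on this nitrogen. An unsubstituted phenyl or a benzyl group there would test whether the anilide link alone carries these steps.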